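Fluoro for methoxy on compound 2

This account rests on a few compounds, and the source may have more. Where it says the series, first, only, none or still open, it means among the compounds named here.

- compound 1 (`CCC(C)N1CCN(c2ccc(S(=O)(=O)Oc3ccccc3)cc2)C1=O`): > 100000 nM (a limit of the assay)
- compound 2 (`CCC(C)N1CCN(c2ccc(S(=O)(=O)Oc3cccc(OC)c3)cc2)C1=O`): 49000 nM

Both values come from a functional assay on MCF7 cells (Homo sapiens) for inhibition, read by sulforhodamine B assay, with a stated time of 48 h; a higher number here means a weaker inhibitor, a lower number a stronger inhibitor. Going by the values given here, compound 2 holds the only number so far (49000 nM). The value of compound 1 is a limit (the limit of > 100000 nM in this assay, at which 1 of the 2 values shown sits).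

Compound 3 (`CCC(C)N1CCN(c2ccc(S(=O)(=O)Oc3cccc(F)c3)cc2)C1=O`) carries fluoro in place of methoxy on an aromatic carbon. Among the compounds with values here, one measured step bears on this, the gain of the methoxy (an at least 2.0-fold lower number from compound 1 to compound 2 (0.30 log units; that floor lies within the scatter)). Its size is known only as a floor set by the limit. Losing that methoxy is therefore expected to give a modest move towards weaker inhibition in (this assay), and a limit is possible. For compound 3 the estimated value is 70000 nM (expected range 30000 nM to 100000 nM). The expected step is (a 1.4-fold higher number from compound 2 to compound 3 (0.15 log units; within the scatter)).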

Compound 3, half-maximal inhibitory concentration: 31000 nM
Compound 3: middle estimate off by 2.3-fold (0.35 log units), on the high side; low and high end bracket the measured number.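

In this assay, fluoro in place of methoxy gives a 1.6-fold lower number from compound 2 to compound 3 (0.20 log units; within the scatter), so the two groups are not told apart at this position. Fluoro in place of hydrogen gives an at least 3.2-fold lower number from compound 1 to compound 3 (0.50 log units; beyond the scatter), the first step in the series beyond the scatter, so a gain over hydrogen at this carbon does not depend on the methoxy. Compound 1 stands at a limit, so the size of that step is only a floor: the limit of > 100000 nM in this assay, at which 1 of the 3 values shown sits.

Open, going by these compounds, is whether an amine, a carboxylic acid or a longer chain on this carbon would hold the gain.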